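From 4-fluorophenyl to 4-nitrophenyl on a shared core

The source may report more compounds than this note shows. Statements on the series, on what has been measured and on what is new or still open speak of the compounds shown alone.

Of the compounds shown here, three of one series have been read in a functional assay on MCF7 cells (Homo sapiens) for antiproliferative activity, read by MTT assay, with a stated time of 72 h; on this read-out lower numbers stand for stronger inhibition and higher numbers for weaker inhibition. Compound 2 (`O=C(N/N=C/c1ccccc1)Nc1ccc(Oc2ccnc3[nH]ccc23)cc1`) gives 1510 nM, compound 3 (`O=C(N/N=C/c1ccc(F)cc1)Nc1ccc(Oc2ccnc3[nH]ccc23)cc1`) gives 3720 nM, and compound 1 (`O=C(N/N=C/c1ccc([N+](=O)[O-])cc1)Nc1ccc(Oc2ccnc3[nH]ccc23)c(F)c1`) gives 4000 nM. Compound 3 therefore lies within the scatter of compound 1, while the number for compound 2 is lower than either.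

The next compound, compound 4 (`O=C(N/N=C/c1ccc([N+](=O)[O-])cc1)Nc1ccc(Oc2ccnc3[nH]ccc23)cc1`), differs from compound 3 by one exchange: nitro in place of fluoro on an aromatic carbon. This puts nitro in place of fluoro on an aromatic carbon, para to a large group. Within the data shown here, the only measured step at this place is fluoro in place of hydrogen, a 2.5-fold higher number from compound 2 to compound 3 (0.39 log units; beyond the scatter), which is modest but beyond the scatter. It shows that the number can respond to a change here, though it does not show how nitro will behave. Among the measured compounds shown here, compound 1, at 4000 nM, is the only measured compound with nitro, and it also carries a further fluoro that compound 4 lacks. For the measured compounds named here, no measured step isolates that difference. Its value nevertheless suggests that nitro need not move the number far from compound 3. The expected step is small, a 1.2-fold lower number from compound 3 to compound 4 (0.09 log units; within the scatter), and is estimated to stay within the scatter. For compound 4 the estimate in this assay is 3000 nM, with an expected range from 1300 nM to 7000 nM.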

Compound 4, half-maximal inhibitory concentration: 15600 nM
For compound 4 the middle estimate is 5.2-fold (0.72 log units) below the measured one, and the stated range ends below it.
By their numbers in this assay, from the lowest: compound 2; then compounds 3 and 1 (each within the scatter of the next); then compound 4.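

Among these compounds, at this place, para to a large group, the choice of substituent clearly matters in this assay: nitro gives a 4.2-fold higher number from compound 3 to compound 4 (0.62 log units; beyond the scatter), and measured against hydrogen it gives a 10-fold higher number from compound 2 to compound 4 (1.01 log units; beyond the scatter), the only large step so far. The comparison with the other nitro compound shows that the further fluoro of compound 1 is no minor detail, since hydrogen in its place gives a 3.9-fold higher number from compound 1 to compound 4 (0.59 log units; beyond the scatter), so compound 1 and compound 4 cannot stand in for each other. It also shows that fluoro in place of hydrogen has no single direction in this small set, for the step goes one way in one pair of compounds and the opposite way in the other: the same change on two cores in this assay, a 2.5-fold higher number (0.39 log units; beyond the scatter) from compound 2 to compound 3 and a 3.9-fold lower number (0.59 log units; beyond the scatter) from compound 4 to compound 1, 9.6-fold (0.98 log units) apart, beyond the scatter of two such steps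

The compounds shown carry only hydrogen, fluoro and nitro at this place, which leaves open where an amine, a methoxy group or a carboxylic acid would fall among these numbers. They also leave open whether the further fluoro of compound 1 would move the number in the same direction with hydrogen or fluoro at this place as it does with nitro.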